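Swapping the benzofuran for phenyl on compound 2

A few compounds are considered here, and "the series" means these few. Any claim that something is new, unique, unknown or untested is made for them only; others in the source may bear on it.

Of the compounds shown here, three sharing one core have been tested in an ADME assay on MRC5 cells (Homo sapiens), read by MTT assay, with a stated time of 72 h; on this read-out higher numbers stand for weaker inhibition and lower numbers for stronger inhibition. Compound 1 `COc1nc(N)nc2c1c(-c1cc3ccccc3o1)cn2[C@@H]1O[C@H](CO)[C@@H](O)[C@H]1O` gives 22700 nM. Compound 2 `Nc1nc(N)c2c(-c3cc4ccccc4o3)cn([C@@H]3O[C@H](CO)[C@@H](O)[C@H]3O)c2n1` gives 78500 nM, and compound 3 `Cc1nc(N)c2c(-c3cc4ccccc4o3)cn([C@@H]3O[C@H](CO)[C@@H](O)[C@H]3O)c2n1` gives 91800 nM. Two steps connect them: a 3.5-fold higher number from compound 1 to compound 2 (0.54 log units; beyond the scatter), and a 1.2-fold higher number from compound 2 to compound 3 (0.07 log units; within the scatter). Compound 2 thus stands second highest of the three numbers; its nearest neighbour is compound 3, within the scatter, while compound 1 is the furthest, beyond the scatter.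

Compound 4 `Nc1nc(N)c2c(-c3ccccc3)cn([C@@H]3O[C@H](CO)[C@@H](O)[C@H]3O)c2n1` has not yet been measured. It differs from compound 2 in one place: phenyl in place of 1-benzofuran-2-yl on an aromatic carbon. Neither measured step touches this position; both concern the other substituent on the core, so nothing measured bears directly on this change. For that reason no step beyond the scatter in either direction is firmly expected, though the absence of any comparable example leaves the range wide. The step from compound 2 to compound 4 in this assay is estimated at a 1.3-fold higher number from compound 2 to compound 4 (0.11 log units; within the scatter). Compound 4 is therefore expected to give about 100000 nM, with a likely range from 40000 nM to 250000 nM.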

Compound 4, half-maximal inhibitory concentration: > 100000 nM
Compound 4: a limit, no number; the forecaster's own chance of this, stated with the estimate: 30%; the middle value sits exactly at the limit.
By their numbers in this assay, from the lowest: compound 1; then compounds 2 and 3 (each within the scatter of the next). At a limit, above all of these: compound 4.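

In this assay compound 4 gives > 100000 nM, which is a limit of the assay and not a number. Going by these compounds alone, this is the first look at this position, since compounds 1, 2 and 3 all carry 1-benzofuran-2-yl there, and replacing that group with phenyl gives an at least 1.2-fold higher number from compound 2 to compound 4 (0.10 log units; that floor lies within the scatter). The change does not bring the number down, but only a floor is known, so the real size of the step cannot be read: the limit of > 100000 nM in this assay, at which 1 of the 4 values shown sits.

Going by these compounds, it remains open whether phenyl would act the same way on compound 1, which carries methoxy in place of amino on the core. On these data alone, it is also open whether a smaller group on this aromatic carbon, such as an amine or a short alkyl chain, would give a lower number than compound 2.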